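The source may hold more compounds than are shown below. What is called first, only, known or untested is meant among the compounds shown, and "the series" means these compounds.

Working notes on the series. In a functional assay on ACHN cells (Homo sapiens) for inhibition, read by sulforhodamine B assay, with a stated time of 48 h (on this read-out lower numbers stand for stronger inhibition of growth and higher numbers for weaker inhibition of growth), compound 1 (`O=C(Cc1csc2nc(-c3ccc(Br)cc3)cn12)N/N=C/c1ccccc1`) gives 10700 nM and compound 2 (`O=C(Cc1csc2nc(-c3ccc(Br)cc3)cn12)N/N=C/c1ccc(O)cc1`) gives 14800 nM with the two numbers within the scatter of each other, so compound 2 stands level with compound 1 on the only data available. Compound 3 (`COc1cccc(OC)c1/C=N/NC(=O)Cc1csc2nc(-c3ccc(Br)cc3)cn12`) changes the group on a carbon with a double bond to nitrogen (2,6-dimethoxyphenyl in place of 4-hydroxyphenyl on a carbon with a double bond to nitrogen) and carries 2,6-dimethoxyphenyl in place of 4-hydroxyphenyl. Within the data shown here, the one measured step (a 1.4-fold higher number from compound 1 to compound 2 (0.14 log units; within the scatter)) is hydroxy in place of hydrogen on an aromatic carbon, and it stays within the scatter. Among the measured compounds shown here, that step offers no guide to 2,6-dimethoxyphenyl, and no compound measured so far carries this group. No direction can therefore be drawn, and in this assay no step beyond the scatter is expected. The expected step (a 1.1-fold lower number from compound 2 to compound 3 (0.06 log units; within the scatter)) is accordingly small, though the uncertainty around it is wide. For compound 3 the estimated value is 13000 nM with an expected range from 5500 nM to 30000 nM on this read-out.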

Compound 3, concentration for 50% growth inhibition: 17000 nM
Compound 3: middle estimate off by 1.3-fold (0.12 log units), on the low side, within the range that was stated.
By their numbers in this assay, from the lowest: compounds 1, 2 and 3 (each within the scatter of the next).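

In this assay, 2,6-dimethoxyphenyl on a carbon with a double bond to nitrogen gives a 1.1-fold higher number from compound 2 to compound 3 (0.06 log units; within the scatter), and the same group gives a 1.6-fold higher number from compound 1 to compound 3 (0.20 log units; within the scatter) when read against phenyl. The earlier pair covered only a hydroxy group in place of hydrogen, whereas these steps show that the three aryl groups at this place stand level, even with a larger group that has no hydrogen-bond donor and carries two methoxy groups. No supporting measurement is available to explain this flat result.

On these data alone, it remains open whether any group at this place can move the number beyond the scatter, for example an aryl group carrying a carboxylic acid or an amine, or a saturated ring such as cyclohexyl in place of the aryl group. All three compounds share the same core, so they also leave open how much of the growth inhibition depends on that core rather than on the group at this position.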